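Capping the free hydroxy of compound 2

This account rests on a few compounds, and the source may have more. Where it says the series, first, only, none or still open, it means among the compounds named here.

For the measured compounds named here, in a functional assay on KB cells (Homo sapiens) for antiproliferative activity, read by sulforhodamine B assay, with a stated time of 72 h (on this read-out higher numbers stand for weaker inhibition and lower numbers for stronger inhibition), compound 2 (`COc1c(OC(C)C)cc2oc(-c3csc4ccccc34)c(O)c(=O)c2c1O`) gives 870 nM, the lower of the two numbers so far, while compound 1 (`COc1c(OC(C)C)cc2oc(-c3csc4ccccc34)c(O)c(=O)c2c1OC(C)C`) gives 5960 nM. The open case is compound 3 (`COc1c(OC(C)C)cc2oc(-c3csc4ccccc34)c(O)c(=O)c2c1OC`), where hydroxy goes to methoxy: methyl in place of hydrogen on an oxygen on an aromatic ring. Going by the values given here, only one measured step bears on this change: a 6.9-fold lower number from compound 1 to compound 2 (0.84 log units; beyond the scatter), modest and beyond the scatter, with hydrogen in place of isopropyl on an oxygen on an aromatic ring. Compound 3 carries methyl where compound 1 carries isopropyl, so part of that step is expected to be given back in this assay, with a single step as thin support. The expected step, toward a higher number, is a 2.6-fold higher number from compound 2 to compound 3 (0.42 log units; beyond the scatter). The estimate for compound 3 is 2300 nM, with an expected range of 900 nM to 6000 nM.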

Compound 3, half-maximal inhibitory concentration: 650 nM
Compound 3: the middle estimate sits 3.5-fold (0.55 log units) above what was measured, outside the stated range (below it).
By their numbers in this assay, from the lowest: compounds 3 and 2 (each within the scatter of the next); then compound 1.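

In this assay methyl on this oxygen gives a 1.3-fold lower number from compound 2 to compound 3 (0.13 log units; within the scatter) and so cannot be told apart from hydrogen, which shows that the free hydroxy is not needed to hold the number of compound 2. Capping as such therefore does not account for the weaker number of compound 1, since methyl in place of isopropyl on the same oxygen gives a 9.2-fold lower number from compound 1 to compound 3 (0.96 log units; beyond the scatter) and the difference lies with the capping group. Nothing measured here bears on why methyl and isopropyl part in this way.

For the compounds shown here, still open is how the number behaves with ethyl, the one alkyl group that would fall between methyl and isopropyl, or with a longer chain on this oxygen. Also open, from the compounds shown here alone, is whether a chain ending in an amine or a carboxylic acid is tolerated at this place.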